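The source may hold more compounds than are shown below. What is called first, only, known or untested is meant among the compounds shown, and "the series" means these compounds.

Measured compounds:
- compound 1 `COc1cc2c(Oc3ccc(NC(=O)c4cc(-c5ccc(F)cc5)ccn4)cc3F)ccnc2cc1OCCCN1CCCCC1`: in a functional assay on HT-29 cells (Homo sapiens) for cytotoxicity, read by MTT assay, with a stated time of 72 h (on this read-out lower numbers stand for stronger inhibition and higher numbers for weaker inhibition), compound 1 gives 1370 nM
- compound 2 `COc1cc2c(Oc3ccc(NC(=O)c4cc(-c5ccc(C(F)(F)F)cc5)ccn4)cc3F)ccnc2cc1OCCCN1CCCCC1`: in this assay compound 2 gives 230 nM

Compound 2 has the lowest of the two numbers in this assay, the step of a 6.0-fold lower number from compound 1 to compound 2 (0.77 log units; beyond the scatter) lying beyond the scatter. Compound 3 `COc1ccc(-c2ccnc(C(=O)Nc3ccc(Oc4ccnc5cc(OCCCN6CCCCC6)c(OC)cc45)c(F)c3)c2)cc1` differs from compound 2 by methoxy in place of trifluoromethyl on an aromatic carbon. Going by the values given here, the only measured step, a 6.0-fold lower number from compound 1 to compound 2 (0.77 log units; beyond the scatter), concerns a different pair of groups, so it bears on this change only loosely: it shows that the group at this place matters, not where methoxy falls. Compound 3 is therefore expected to give a higher number than compound 2, a step of about a 3.0-fold higher number from compound 2 to compound 3 (0.48 log units; beyond the scatter). For compound 3 the estimate in this assay is 700 nM, within 200 nM to 2500 nM.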

Compound 3, half-maximal inhibitory concentration: 690 nM
For compound 3 the middle estimate is 1.0-fold (0.01 log units) above the measured one; low and high end bracket the measured number.
By their numbers in this assay, from the lowest: compound 2; then compounds 3 and 1 (each within the scatter of the next).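

In this assay, the step of a 3.0-fold higher number from compound 2 to compound 3 (0.48 log units; beyond the scatter) shows that methoxy, like fluoro, gives a higher number than trifluoromethyl at this place, so compound 2 stands apart from both other compounds. The step of a 2.0-fold lower number from compound 1 to compound 3 (0.30 log units; within the scatter) means that methoxy and fluoro cannot be told apart here, although the two groups differ in kind. Among the three compounds, then, only trifluoromethyl separates from the rest. As far as these compounds go, what an amine, a carboxylic acid or a longer alkyl chain would give at this place remains open. No measurement among those available accounts for these differences.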